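The compounds below may be only part of what the source reports. "The series", "measured", "known", "first", "only" and "open" are said of these compounds alone.

In an ADME assay on Vero cells (Chlorocebus sabaeus) for cytotoxicity, read by MTT assay, with a stated time of 72 h (a higher number here means that more compound is tolerated, a lower number that less compound is tolerated), compound 3 `CC1(C)C=Cc2c(ccc(C(=O)/C=C/c3ccccn3)c2O)O1` stands lowest of the three measured at 20500 nM, with compound 2 `CC1(C)C=Cc2c(ccc(C(=O)/C=C/c3ccc(C#N)cc3)c2O)O1` at 80200 nM and compound 1 `CC1(C)C=Cc2c(ccc(C(=O)/C=C/c3ccc(F)cc3)c2O)O1` at 158000 nM. Compound 4 `CC1(C)C=Cc2c(ccc(C(=O)/C=C/c3cccnc3)c2O)O1` carries pyridin-3-yl in place of pyridin-2-yl on the same chain carbon (pyridin-3-yl in place of pyridin-2-yl on a double-bonded chain carbon bound to a double-bonded chain carbon). The closest evidence is the change to pyridin-2-yl, with modest steps beyond the scatter: a 7.7-fold lower number from compound 1 to compound 3 (0.89 log units; beyond the scatter) and a 3.9-fold lower number from compound 2 to compound 3 (0.59 log units; beyond the scatter). By contrast, a 2.0-fold lower number from compound 1 to compound 2 (0.29 log units; within the scatter) stays within the scatter. Going by the values given here, no measured step compares the two pyridinyl groups, so the size of this change remains open. The expected result in this assay is no step beyond the scatter, with a slight lean towards a higher number: a 1.5-fold higher number from compound 3 to compound 4 (0.17 log units; within the scatter). For compound 4 the estimated value is 30000 nM, within an expected range of 11000 nM to 80000 nM.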

Compound 4, half-maximal cytotoxic concentration: 8600 nM
Estimate against measurement, compound 4: 3.5-fold (0.54 log units) above, outside the stated range (below it).
By their numbers in this assay, from the lowest: compound 4; then compound 3; then compounds 2 and 1 (each within the scatter of the next).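

In this assay, pyridin-3-yl and pyridin-2-yl are told apart at this chain carbon despite having the same atom and donor and acceptor counts (a 2.4-fold lower number from compound 3 to compound 4 (0.38 log units; beyond the scatter)). Going by these compounds alone, compound 4 also stands further from the substituted phenyl compounds (a 9.3-fold lower number from compound 2 to compound 4 (0.97 log units; beyond the scatter); an 18-fold lower number from compound 1 to compound 4 (1.26 log units; beyond the scatter)), and the latter is the only large step among the new ones. No measurement shown explains the gap between the two pyridinyl groups.

Open, going by these compounds, is where pyridin-4-yl or a 4-aminophenyl group would fall at this chain carbon. Also open, on these data alone, is whether the order of the two pyridinyl groups holds in other cell lines.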